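The source may hold more compounds than are shown below. What is called first, only, known or untested is meant among the compounds shown, and "the series" means these compounds.

Working notes on the series, an assay on isolated protein for inhibition of Amine oxidase [flavin-containing] A (Homo sapiens), read by fluorescence; a higher number here means a weaker inhibitor, a lower number a stronger inhibitor. Of the compounds shown here, three sharing the same core have been measured. Compound 1 `O=C(/C=C/c1nccs1)c1cc(O)c(O)c([N+](=O)[O-])c1` gives 69600 nM. Compound 2 `CC(=O)N1N=C(c2cc(O)c(O)c([N+](=O)[O-])c2)CC1c1ccco1` gives 98000 nM, and compound 3 `CC(=O)N1N=C(c2cc(O)c(O)c([N+](=O)[O-])c2)CC1c1nccs1` gives 84600 nM. Compound 3 thus holds the second highest of the three numbers, yet both of its gaps lie within the scatter, so no order among the three can be read. For the measured compounds named here, the only single-point step measured so far is a 1.2-fold lower number from compound 2 to compound 3 (0.06 log units; within the scatter), which did not move the number beyond the scatter.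

Compound 4 `CC(=O)N1N=C(c2cc(O)c(O)c([N+](=O)[O-])c2)CC1c1ccoc1` is the next member. Relative to compound 3 the change is furan-3-yl in place of 1,3-thiazol-2-yl on a saturated ring carbon. The step that bears on it is a 1.2-fold lower number from compound 2 to compound 3 (0.06 log units; within the scatter), also an exchange of one five-membered heteroaryl for another on that saturated ring carbon; it stayed within the scatter. A further exchange of the same kind is therefore expected to give no step beyond the scatter in this assay, in either direction. For compound 4 the expected value in this assay is 85000 nM, within a range of 45000 nM to 160000 nM. The step this estimate implies is a 1.0-fold higher number from compound 3 to compound 4 (0.00 log units; within the scatter), expected to stay within the scatter.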

Compound 4, half-maximal inhibitory concentration: 90900 nM
Beside the measured number, compound 4's estimate is 1.1-fold (0.03 log units) below it; the range from low to high includes it.
By their numbers in this assay, from the lowest: compounds 1, 3, 4 and 2 (each within the scatter of the next).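

In this assay, the series of exchanges on the saturated ring carbon now covers three five-membered heteroaryl groups: a 1.1-fold higher number from compound 3 to compound 4 (0.03 log units; within the scatter) and a 1.1-fold lower number from compound 2 to compound 4 (0.03 log units; within the scatter) both stay within the scatter. For the compounds shown here, the second of these steps keeps the furan and changes only its point of attachment, furan-3-yl in place of furan-2-yl, so this kind of change also leaves the number within the scatter at this position, which the earlier compounds could not show. Nothing available explains this flat response.

Compounds 2, 3 and 4 carry only five-membered heteroaryl groups on this carbon, all with the same acetyl group. On these data alone, whether an amine, a carboxylic acid or a longer chain at this position would give a step beyond the scatter remains open.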